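The compounds below may be only part of what the source reports. "The series", "measured", "known", "first", "only" and "open" are said of these compounds alone.

In a functional assay on KB cells (Homo sapiens) for antiproliferative activity, read by sulforhodamine B assay, with a stated time of 3 days (a higher number here means that more compound is needed for the effect, a lower number that less compound is needed), compound 1 `CCCCc1ccc(-c2cc(=O)c3c(o2)C(CC)(CC)C(=O)C(CC)=C3O)cc1` gives 111 uM, compound 2 `CCC1=C(O)c2c(oc(-c3ccc(C(F)(F)F)cc3)cc2=O)C(CC)(CC)C1=O` gives 35.7 uM and compound 3 `CCC1=C(O)c2c(oc(-c3ccc(O)cc3)cc2=O)C(CC)(CC)C1=O` gives 20.6 uM. Compound 3 stands at the low end of these numbers, but not alone: a 1.7-fold lower number from compound 2 to compound 3 (0.24 log units; within the scatter) stays within the scatter, while a 5.4-fold lower number from compound 1 to compound 3 (0.73 log units; beyond the scatter) goes beyond it. Compound 4 `CCC1=C(O)c2c(oc(-c3cccc(C)c3)cc2=O)C(CC)(CC)C1=O` carries 3-methylphenyl in place of 4-hydroxyphenyl, (3-methylphenyl in place of 4-hydroxyphenyl on an aromatic carbon). The nearest guides are the measured swaps on that aromatic group, all modest or smaller, such as a 3.1-fold lower number from compound 1 to compound 2 (0.49 log units; beyond the scatter). Within the data shown here, none of the measured compounds carries this group, so only a small rise in this assay is expected, hardly beyond the scatter. For compound 4 the estimate is 40 uM, within a range of 17 uM to 95 uM. This means an expected 1.9-fold higher number from compound 3 to compound 4 (0.29 log units; within the scatter).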

Compound 4, concentration for half-maximal effect: 49.7 uM
Beside the measured number, compound 4's estimate is 1.2-fold (0.09 log units) below it, within the range that was stated.
By their numbers in this assay, from the lowest: compounds 3, 2 and 4 (each within the scatter of the next, the first and the last beyond it); then compound 1.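

In this assay, 3-methylphenyl in place of 4-hydroxyphenyl gives a 2.4-fold higher number from compound 3 to compound 4 (0.38 log units; beyond the scatter), a modest step. This swap removes the hydroxy group, with its hydrogen-bond donor and acceptor, and also changes where the ring carries its substituent, so this single step cannot show which of these changes matters. No measurement at hand explains the step. A 4-methylphenyl or 3-hydroxyphenyl group could separate the two changes. On these data alone, how an amine or a carboxylic acid on this ring would behave also stays open.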